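This account rests on a few compounds, and the source may have more. Where it says the series, first, only, none or still open, it means among the compounds named here.

In a functional assay on LoVo cells (Homo sapiens) for inhibition, read by MTT assay, with a stated time of 24 h (on this read-out lower numbers stand for stronger inhibition and higher numbers for weaker inhibition), compound 1 `CC1(C)[C@H]2CC[C@]1(C)N(Cc1cn(-c3cccc(Cl)c3)nn1)C(=O)C2` gives 70 nM and compound 2 `Cc1ccc(-n2cc(CN3C(=O)C[C@@H]4CC[C@@]3(C)C4(C)C)nn2)cc1` gives 50 nM. Going by the values given here, these are the only two numbers so far, and they lie within the usual scatter of repeated measurements, so compound 2 cannot be told apart from compound 1.

Compound 3 `Cc1ccccc1-n1cc(CN2C(=O)C[C@@H]3CC[C@@]2(C)C3(C)C)nn1` has the same atoms as compound 2, joined differently: 2-methylphenyl in place of 4-methylphenyl on an aromatic nitrogen. In words, it carries 2-methylphenyl in place of 4-methylphenyl on an aromatic nitrogen.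

Among the compounds with values here, one measured step bears on this change, as it also swaps one group for another on that aromatic nitrogen: a 1.4-fold lower number from compound 1 to compound 2 (0.15 log units; within the scatter). Within the data shown here, that step stayed within the scatter, but it is only a single example, and no measured compound carries 2-methylphenyl. The data therefore give only weak guidance, and no clear shift beyond the scatter is expected in this assay. The expected change is a 1.2-fold higher number from compound 2 to compound 3 (0.08 log units; within the scatter), which is too small to set a direction with any confidence. Compound 3 is estimated at 60 nM, with an expected range from 20 nM to 200 nM.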

Compound 3, half-maximal inhibitory concentration: 80 nM
Estimate against measurement, compound 3: 1.3-fold (0.12 log units) below, and the stated range covers the measured number.
By their numbers in this assay, from the lowest: compounds 2, 1 and 3 (each within the scatter of the next).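

In this assay, putting 2-methylphenyl in place of 4-methylphenyl on the aromatic nitrogen gives a 1.6-fold higher number from compound 2 to compound 3 (0.20 log units; within the scatter), and putting it in place of 3-chlorophenyl gives a 1.1-fold higher number from compound 1 to compound 3 (0.06 log units; within the scatter). Together with the earlier step, this places all three compounds within the scatter of one another, so the shift of the methyl group from the 4-position to the 2-position of the phenyl ring produces no difference that can be told apart from repeat-measurement noise, and the same holds for the exchange of the 3-chlorophenyl group. No measurement shown here accounts for these results or tells what the phenyl group contributes to the activity.

On these data alone, all three compounds carry a phenyl ring with one small group on it, so it remains open whether the numbers would stay this close with an unsubstituted phenyl ring, a pyridine ring, a benzyl group or a plain butyl chain on that nitrogen, or with an amine or a carboxylic acid on the phenyl ring. The compounds shown also leave open how the numbers respond to any change in the shared core, which is identical in all three.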